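Trimming the Aryl Cap: Pentamethylphenyl to Dimethylphenyl

A few compounds are considered here, and "the series" means these few. Any claim that something is new, unique, unknown or untested is made for them only; others in the source may bear on it.

Measured so far:
- compound 1, `Cc1oc(-c2c(C)c(C)c(C)c(C)c2C)nc1CN1CCC(C(=O)NCCCN2C[C@H](C)C[C@H](C)C2)CC1`: 8180 nM
- compound 2, `Cc1ccccc1-c1nc(CN2CCC(C(=O)NCCCN3CCCC(C(C)C)C3)CC2)c(C)o1`: 5820 nM

In an ADME assay on Huh7.5.1 cells (Homo sapiens) for cytotoxicity, read by ATP content, with a stated time of 48 h (on this read-out lower numbers stand for higher toxicity in this test and higher numbers for lower toxicity in this test), compound 1 gives 8180 nM, the higher of the two numbers, but compound 2 with 5820 nM sits within the scatter of it, so the two cannot be told apart. Compound 3, `Cc1ccc(-c2nc(CN3CCC(C(=O)NCCCN4C[C@H](C)C[C@H](C)C4)CC3)c(C)o2)cc1C`, has not been tested. It differs from compound 1 by 3,4-dimethylphenyl in place of 2,3,4,5,6-pentamethylphenyl on an aromatic carbon. Going by the values given here, no measured pair shows this kind of change, so no size of step can be read off. Compound 3 is expected to stay close to compound 1, with the step of a 1.2-fold lower number from compound 1 to compound 3 (0.07 log units; within the scatter) not exceeding the scatter. The estimate for compound 3 is 7000 nM, within 3500 nM to 14000 nM.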

Compound 3, half-maximal cytotoxic concentration: 6910 nM
For compound 3 the middle estimate is 1.0-fold (0.01 log units) above the measured one; low and high end bracket the measured number.
By their numbers in this assay, from the lowest: compounds 2, 3 and 1 (each within the scatter of the next).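

Going by these compounds alone, this is the first pair that differs in one place only. In this assay, 3,4-dimethylphenyl in place of 2,3,4,5,6-pentamethylphenyl gives a 1.2-fold lower number from compound 1 to compound 3 (0.07 log units; within the scatter), so for this pair, the smaller aryl group on the shared core leaves the cytotoxicity reading unchanged within the scatter. No supporting evidence is available to explain this result. Still open, on these data alone, is whether a plain phenyl group, or a phenyl group carrying an amine or a carboxylic acid, would shift the number in this assay beyond the scatter.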